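Benzyl variation on the triazole-linked biotin series

The compounds below may be only part of what the source reports. "The series", "measured", "known", "first", "only" and "open" are said of these compounds alone.

Measured compounds in an assay on isolated protein for inhibition of biotin--protein ligase (Homo sapiens), read by scintillation counting, with a stated time of 10 min; on this read-out lower numbers stand for stronger inhibition and higher numbers for weaker inhibition:
Compound 1, `COc1ccccc1Cn1cc(CCCCC[C@@H]2SC[C@@H]3NC(=O)N[C@@H]32)nn1`, gives only a limit, > 16000 nM.
Compound 2, `Nc1cccc(Cn2cc(CCCCC[C@@H]3SC[C@@H]4NC(=O)N[C@@H]43)nn2)c1`, gives only a limit, > 16000 nM.
Compound 3, `Cc1cccc(Cn2cc(CCCCC[C@@H]3SC[C@@H]4NC(=O)N[C@@H]43)nn2)c1`, gives only a limit, > 16000 nM.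

Compound 3 stands at the limit of > 16000 nM in this assay, at which 3 of the 3 values shown sit, so its position is a limit and not a number. The steps among the measured compounds, a step that the two limits leave unreadable from compound 1 to compound 2, a step that the two limits leave unreadable from compound 1 to compound 3 and a step that the two limits leave unreadable from compound 2 to compound 3, are all unreadable for the same reason: both ends sit at the limit.

Compound 4, `O=C1N[C@H]2[C@H](CS[C@H]2CCCCCc2cn(Cc3ccccc3F)nn2)N1`, differs from compound 3 by 2-fluorophenyl in place of 3-methylphenyl on a saturated chain carbon bound to an aromatic nitrogen. The measured steps bear on this change only in showing that three different substituents on the same position all leave the compound at the limit in this assay, with no readable direction or size.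

The step expected here, a step that the limit leaves unreadable from compound 3 to compound 4, is therefore nothing readable beyond the limit. Compound 4 is expected to give 30000 nM, within 10000 nM to 100000 nM, and most probably to be reported again as a limit.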

Compound 4, inhibition constant: > 16000 nM
Compound 4: no number, only a limit; the forecaster's own chance of this, stated with the estimate: 85%; the middle value is on the limit's open side.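

The steps linking compound 4 with compound 1, compound 2 and compound 3 cannot be read in this assay, because each compound gives only a limit: the limit of > 16000 nM in this assay, at which 4 of the 4 values shown sit.

The compounds shown leave open whether any benzyl group on the shared core gives a readable value, and which benzyl changes matter.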